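The source may hold more compounds than are shown below. What is called first, only, known or untested is meant among the compounds shown, and "the series" means these compounds.

Measured compounds:
Compound 1, `O=C(CN(Cc1ccc(Cl)cc1)C1CCCCC1)Nc1cc(F)cc(F)c1`, in an assay on HEK293 cells for inhibition of sodium- and chloride-dependent glycine transporter 1 (Homo sapiens), read by scintillation proximity assay (a lower number here means a stronger inhibitor, a higher number a weaker inhibitor), gives > 25100 nM, which is a limit of the assay and not a number.
Compound 2, `O=C(CN(C(=O)C1CCCCC1)C1CCCCC1)Nc1cc(F)cc(F)c1`, in this assay gives 6310 nM.
Compound 3, `O=C(CN(C(=O)c1cccnc1)C1CCCCC1)Nc1cc(F)cc(F)c1`, in this assay gives > 25100 nM, again only a limit of the assay.

Compound 3 thus stands at the weak end of the numbers shown, where it cannot be told apart from compound 1, as both rest at the limit of > 25100 nM in this assay, at which 2 of the 3 values shown sit. Compound 4, `O=C(CN(C(=O)c1ccccc1Cl)C1CCCCC1)Nc1cc(F)cc(F)c1`, differs from compound 3 in one place: 2-chlorophenyl in place of pyridin-3-yl on a carbonyl carbon. Among the measured compounds shown here, two measured steps bear on this change. an at least 3.9-fold higher number from compound 2 to compound 3 (0.59 log units; beyond the scatter) shows that putting pyridin-3-yl in place of cyclohexyl on the same carbonyl carbon weakened the inhibitor, so moving away from pyridin-3-yl may pull the number back down. an at least 3.9-fold lower number from compound 1 to compound 2 (0.59 log units; beyond the scatter) shows that a carbonyl-linked ring on that nitrogen can give a readable number at all. a step that the two limits leave unreadable from compound 1 to compound 3 adds nothing, as both ends are limits. Compound 3 itself is only a limit, so the size of the step cannot be fixed; a modest drop in the number is expected, an at least 2.5-fold lower number from compound 3 to compound 4 (0.39 log units; beyond the scatter). Compound 4 is expected to give about 10000 nM, between 3000 nM and 30000 nM, with a fair chance that only a limit is reported again.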

Compound 4, half-maximal inhibitory concentration: 20000 nM
For compound 4 the middle estimate is 2.0-fold (0.30 log units) below the measured one; measured number inside the range.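

Compound 4 gives this carbonyl carbon a readable number for an aromatic ring. Putting 2-chlorophenyl in place of cyclohexyl gives a 3.2-fold higher number from compound 2 to compound 4 (0.50 log units; beyond the scatter), so in this assay this ring, like pyridin-3-yl, does worse than the saturated cyclohexyl ring of compound 2. The comparisons with the two weakest entries are an at least 1.2-fold lower number from compound 3 to compound 4 (0.09 log units; that floor lies within the scatter) and an at least 1.2-fold lower number from compound 1 to compound 4 (0.09 log units; that floor lies within the scatter); the floors of both steps lie within the usual scatter, so neither shows a real gain, and both start from a limit of the assay: the limit of > 25100 nM in this assay, at which 2 of the 4 values shown sit.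

From the compounds shown here alone, it stays open whether the chlorine or the carbon-only ring itself sets the number of compound 4, a question that a plain phenyl group on the same carbonyl carbon could help to settle. Going by these compounds, it is also open whether a cyclopentyl ring or an open chain such as tert-butyl in this place would match cyclohexyl or improve on it.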